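Extending the ether chain of compound 2 with a sulfamoylamino group

The source may hold more compounds than are shown below. What is called first, only, known or untested is meant among the compounds shown, and "the series" means these compounds.

Two members of the series have numbers in an assay for inhibition of Indoleamine 2,3-dioxygenase 1 (Homo sapiens), read by fluorescence, with a stated time of 24 h; a higher number here means a weaker inhibitor, a lower number a stronger inhibitor. Compound 1 `NS(=O)(=O)CC(=O)NCCSc1nonc1/C(=N/O)Nc1cccc(Cl)c1` gives 10 nM in this assay. Compound 2 `COc1nonc1/C(=N/O)Nc1ccc(F)c(Br)c1` gives 39 nM in this assay, the higher of the two numbers; the gap to compound 1 lies beyond the usual scatter. Within the data shown here, no pair of measured compounds differs in one place, so no single step can be read from the data.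

Compound 3 `NS(=O)(=O)NCCOc1nonc1/C(=N/O)Nc1ccc(F)c(Br)c1` is not yet measured. It differs from compound 2 in one place: (sulfamoylamino)methyl in place of hydrogen on a saturated chain carbon bound to an oxygen on an aromatic ring. The change lengthens the ether chain of compound 2 and brings in a sulfamoyl-bearing terminus, a motif that also appears at the end of the chain in compound 1.

The expectation for compound 3 in this assay rests on compound 1, whose longer chain ending in a sulfamoyl group goes with 10 nM. The step from compound 2 to compound 3 is therefore expected to lower the number modestly, a 2.2-fold lower number from compound 2 to compound 3 (0.34 log units; beyond the scatter), by an amount at the edge of the scatter. Compound 3 is estimated at 18 nM in this assay, within a range from 6 nM to 55 nM.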

Compound 3, half-maximal inhibitory concentration: 12 nM
Estimate against measurement, compound 3: 1.5-fold (0.18 log units) above; low and high end bracket the measured number.
By their numbers in this assay, from the lowest: compounds 1 and 3 (each within the scatter of the next); then compound 2.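

In this assay, among these compounds, the change from methoxy to 2-(sulfamoylamino)ethoxy gives a 3.3-fold lower number from compound 2 to compound 3 (0.51 log units; beyond the scatter) and provides the first single-place step. The position on the saturated chain carbon bound to an oxygen on an aromatic ring therefore accepts the (sulfamoylamino)methyl extension with a lower number rather than a loss of inhibition, at least with the aryl group of compound 2 held constant. No supporting measurement is available to explain the step, which remains an observation about these two structures.

This single step does not separate the contribution of the longer chain from that of the sulfamoylamino terminus, so a simple ethoxy group, a 2-aminoethoxy group or a chain ending in a carboxylic acid would be needed to divide the effect. Also open, on these data alone, are whether a longer chain carrying the same terminus keeps the lower number and whether the step holds with a different substituted phenyl group on the shared core.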